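Sulfonamide aryl exchange in a cytotoxicity series

The compounds below may be only part of what the source reports. "The series", "measured", "known", "first", "only" and "open" are said of these compounds alone.

Measured so far:
compound 1 `CC1CCN(C2CCN(S(=O)(=O)c3ccccc3-c3ccc(C(F)(F)F)cc3)CC2)CC1` — > 5000 nM
compound 2 `CC1CCN(C2CCN(S(=O)(=O)c3nccn3C)CC2)CC1` — > 10000 nM

In an ADME assay on HCT-116 cells (Homo sapiens) for cytotoxicity, read by CellTiter-Glo, with a stated time of 72 h (a lower number here means a stronger inhibitor, a higher number a weaker inhibitor), compound 1 gives > 5000 nM, which is a limit of the assay and not a number. In this assay compound 2 gives > 10000 nM, again a limit rather than a measured number. Compound 2 thus sits at the limit of > 10000 nM in this assay, at which 1 of the 2 values shown sits, and compound 1 sits at the limit of > 5000 nM in this assay, at which 1 of the 2 values shown sits. Both entries are limits, so no order between compound 1 and compound 2 can be read from them.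

Compound 3 `CC1CCN(C2CCN(S(=O)(=O)c3ccc(Br)c(Cl)c3)CC2)CC1` is not yet measured. It differs from compound 2 by 4-bromo-3-chlorophenyl in place of 1-methyl-1H-imidazol-2-yl on a sulfonyl sulfur. Among the measured compounds shown here, no measured step between compounds exists, so the size of the change is unknown; the expectation is for no step beyond the scatter, with a step from compound 2 to compound 3 of a number no higher from compound 2 to compound 3 (the limit leaves the size open) taken as the working guess. Compound 3 is therefore expected to give about 10000 nM, within a range of 3000 nM to 30000 nM, most likely again reported only as a limit.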

Compound 3, half-maximal inhibitory concentration: > 5000 nM
Compound 3: only a limit was reported; the forecaster's own chance of this, stated with the estimate: 70%; the middle value is on the limit's open side.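

In this assay, among the compounds shown here, compound 2 and compound 3 are both reported only as limits, so no step between them can be read. The compounds shown leave open whether 4-bromo-3-chlorophenyl in place of 1-methyl-1H-imidazol-2-yl on a sulfonyl sulfur changes cytotoxicity at all.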